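This account rests on a few compounds, and the source may have more. Where it says the series, first, only, none or still open, it means among the compounds named here.

Compound 1 `O=C(CCN1C(=O)CSc2ccccc21)N1CCN(c2ccc(F)cc2)CC1` and compound 2 `O=C(CCN1C(=O)CSc2ccccc21)N1CCN(c2ccccc2)CC1` share one core and differ only on the aryl ring. In a functional assay (MiaPaCa cells, Homo sapiens) for inhibition, read by sulforhodamine B assay, with a stated time of 48 h (a lower number here means a stronger inhibitor of growth, a higher number a weaker inhibitor of growth), compound 1 reaches only a limit of the assay, > 100000 nM. In this assay compound 2 likewise reaches only a limit, > 100000 nM. The step that the two limits leave unreadable from compound 1 to compound 2 cannot be read since (the limit of > 100000 nM in this assay, at which 2 of the 2 values shown sit). Compound 2 thus stands at the limit, with no number attached to it. Compound 3 `COc1ccccc1N1CCN(C(=O)CCN2C(=O)CSc3ccccc32)CC1` differs from compound 2 by methoxy in place of hydrogen on an aromatic carbon. No measured step bears on this change: the only step present, a step that the two limits leave unreadable from compound 1 to compound 2, gives neither size nor direction, so nothing shown supports a move beyond the scatter. With both measured compounds at the limit, compound 3 is expected to sit there too, with an expected step that the limit leaves unreadable from compound 2 to compound 3. The estimate for compound 3 in this assay is 150000 nM, range 30000 nM to 1000000 nM.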

Compound 3, concentration for 50% growth inhibition: 34900 nM
Compound 3: the middle estimate sits 4.3-fold (0.63 log units) above what was measured; measured number inside the range.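

In this assay, within the data shown here, the change to 2-methoxyphenyl is the first to bring a compound off the limit, giving an at least 2.8-fold lower number from compound 2 to compound 3 (0.45 log units; beyond the scatter). Set against the 4-fluorophenyl group, the same aryl change gives an at least 2.8-fold lower number from compound 1 to compound 3 (0.45 log units; beyond the scatter). Both sizes are only minimum gaps and not measured distances, because the starting compounds carry a limit and no number: the limit of > 100000 nM in this assay, at which 2 of the 3 values shown sit.

Still open, on these data alone, is whether methoxy at another place on the ring, or an ethoxy group or a chlorine on the same aromatic carbon, would give a step of similar size. Also open, as far as these compounds go, is whether the gain would hold with changes away from the aryl ring, such as a longer chain or an added amine on the shared core.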